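A few compounds are considered here, and "the series" means these few. Any claim that something is new, unique, unknown or untested is made for them only; others in the source may bear on it.

Compound 1 `CC(C)(C)OC(=O)NCCCCNC(=O)CN1CN(c2ccccc2)C2(CCN(C(=O)c3ccc(C(C)(C)C)cc3)CC2)C1=O` is the parent of this step. In an assay on HEK293 cells for displacement of a labelled ligand from NPC1-like intracellular cholesterol transporter 1 (Homo sapiens) (a higher number here means a weaker inhibitor, a lower number a stronger inhibitor), compound 1 is recorded as "not determined" (no result reported); no result was reported for it, so it stands nowhere on the scale and gives no anchor of its own. Going by the values given here, the only measured member of the series is compound 2 `O=C(CN1CN(c2ccccc2)C2(CCN(C(=O)c3ccc(C4CCCCC4)cc3)CC2)C1=O)N1CCCCC1`, which shares the core of compound 1 but carries a different aryl substituent and a different amide. In this assay, among the compounds with values here, compound 2 gives 1100 nM, and that value is the sole measured point the step can be set against.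

Compound 3 `CC(C)(C)c1ccc(C(=O)N2CCC3(CC2)C(=O)N(CC(=O)NCCCCNS(C)(=O)=O)CN3c2ccccc2)cc1` is the compound to be measured. It differs from compound 1 in one place (methylsulfonyl in place of tert-butoxycarbonyl on an amine nitrogen). The change keeps the count of hydrogen-bond donors and acceptors on the amine nitrogen the same and shortens the group by three heavy atoms, with no ring removed or added.

With no number for compound 1, the direction of the step cannot be read from the data; no change beyond the scatter is expected for compound 3 in this assay relative to what compound 2 shows there. Compound 3 is estimated at 2000 nM in this assay, within 500 nM to 8000 nM.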

Compound 3, half-maximal inhibitory concentration: 4500 nM
Compound 3: middle estimate off by 2.3-fold (0.35 log units), on the low side; low and high end bracket the measured number.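

No new step can be read for compound 3 in this assay: compound 1 has no number there, and compound 2 differs from compound 3 in more than one place. The compounds shown leave open what exchanging tert-butoxycarbonyl for methylsulfonyl on the amine nitrogen does to the read-out. No supporting evidence bears on this result.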